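Bicyclic amide replacement on the shared core

The compounds below may be only part of what the source reports. "The series", "measured", "known", "first", "only" and "open" are said of these compounds alone.

Series around the shared core of compound 2 `O=C(c1c[nH]c2ccccc12)N1CCc2nc(COc3ccccc3)oc2C1`. In a functional assay on HEK293 cells for positive allosteric modulation of metabotropic glutamate receptor 5 (Homo sapiens), read by calcium flux (on this read-out lower numbers stand for smaller maximal responses and higher numbers for larger maximal responses), compound 2 gives 71%, the second highest of the three numbers measured. Compound 3 `Cn1cc(C(=O)N2CCc3nc(COc4ccccc4)oc3C2)c2ccccc21` gives 70% in this assay, and compound 1 `O=C(c1ccc(F)cc1)N1CCc2nc(COc3ccccn3)oc2C1` gives 75%; both lie within the usual scatter of the number for compound 2. Going by the values given here, the only step between compounds that differ in one place is a number 1 percentage points lower from compound 2 to compound 3 (within the scatter), and it stays within the scatter.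

Compound 4 `O=C(c1n[nH]c2ncccc12)N1CCc2nc(COc3ccccc3)oc2C1` is not yet measured. It differs from compound 2 in the group on the carbonyl carbon: a group of 9 heavy atoms (6 carbon, 3 nitrogen; one five-membered aromatic ring with 2 hetero atoms, one six-membered aromatic ring with 1 hetero atom) in place of a group of 9 heavy atoms (8 carbon, 1 nitrogen; one five-membered aromatic ring with 1 hetero atom, one six-membered aromatic ring of carbon only), on a carbonyl carbon. Among the compounds with values here, no measured step exchanges the aromatic group on the carbonyl carbon, so the step from compound 2 to compound 3 bears on the present change only in showing that a small alteration at that end left the number within the scatter. The three measured compounds, with different groups on the carbonyl carbon, also lie within the scatter of one another. The expectation is therefore no step beyond the scatter. Compound 4 is expected to give 70% in this assay, with a range from 55% to 85%. The implied step is estimated as a number 1 percentage points lower from compound 2 to compound 4 (within the scatter).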

Compound 4, largest response reached (reported as percent of maximum), in percent of the reference or control that the assay uses: 73%
Beside the measured number, compound 4's estimate is 3 percentage points below it; the measured number falls inside the stated range.
By their numbers in this assay, from the lowest: compounds 3, 2, 4 and 1 (each within the scatter of the next).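

In this assay, the exchange of the aromatic group on the carbonyl carbon gives a number 2 percentage points higher from compound 2 to compound 4 (within the scatter); earlier steps did not exchange this group. With the amide-type nitrogen in a ring as the carbonyl carbon's other neighbour, 1H-indol-3-yl can therefore give way to the group of 9 heavy atoms with 3 nitrogen, hetero atoms in both aromatic rings and 2 hydrogen-bond acceptors, with no step beyond the scatter on this read-out. Nothing at hand bears on why the number holds across this change.

Still open, going by these compounds, is whether a carboxylic acid or an amine carried on the group at the carbonyl carbon would give a step beyond the scatter. Also open, on these data alone, is whether methyl in place of hydrogen on an aromatic nitrogen of the group in compound 4 would match a number 1 percentage points lower from compound 2 to compound 3 (within the scatter).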